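From an Amide to an Alcohol on the Shared Core

The source may report more compounds than this note shows. Statements on the series, on what has been measured and on what is new or still open speak of the compounds shown alone.

Of the compounds shown here, three built on one shared core have been measured in an assay on Cortex with Norepinephrine transporter (Rattus norvegicus) as the target; on this read-out lower numbers stand for stronger inhibition and higher numbers for weaker inhibition. Compound 1 `CN1CC[C@H](c2ccc(Cl)cc2)[C@@H](C(=O)OCCCCCc2ccccc2)C1` gives 382 nM. Compound 2 `CCOC(=O)C[C@H]1CN(C)CC[C@@H]1c1ccc(Cl)cc1` gives 101 nM, and compound 3 `CN1CC[C@H](c2ccc(Cl)cc2)[C@@H](CC(=O)N(C)C)C1` gives 46 nM, the lowest of the three numbers; its nearest neighbour is compound 2 and its furthest is compound 1. Within the data shown here, the only step between two compounds differing in a single place, a 2.2-fold lower number from compound 2 to compound 3 (0.34 log units; beyond the scatter), is a change on a carbonyl carbon while the carbonyl itself stays in place.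

Compound 4 `CN1CC[C@H](c2ccc(Cl)cc2)[C@@H](CCCO)C1` has not yet been measured. It differs from compound 3 in one place: 2-hydroxyethyl in place of dimethylcarbamoyl on a saturated chain carbon bound to a saturated ring carbon. Among the measured compounds shown here, no measured step has this shape: the step from compound 2 to compound 3 swapped the group attached to a carbonyl, whereas here the whole carbonyl leaves and a hydrogen-bond donor enters. For the measured compounds named here, the one measured step was modest, and the three numbers lie fairly close together, so a dramatic move is not the first expectation. Going by the values given here, with no direct precedent for removing the carbonyl, a modest drift toward weaker binding is expected, a 2.0-fold higher number from compound 3 to compound 4 (0.29 log units; within the scatter). The estimate for compound 4 is 90 nM, with a range from 25 nM to 350 nM.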

Compound 4, inhibition constant: 564 nM
Compound 4: middle estimate off by 6.3-fold (0.80 log units), on the low side; measured number outside the range, above it.
By their numbers in this assay, from the lowest: compound 3; then compound 2; then compounds 1 and 4 (each within the scatter of the next).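

In this assay, this place on the shared core proves far more sensitive to replacing the whole carbonyl-bearing group than to changing what sits on the carbonyl: replacing dimethylcarbamoyl with 2-hydroxyethyl gives a 12-fold higher number from compound 3 to compound 4 (1.09 log units; beyond the scatter) as a large step, whereas the earlier swap of ethoxy for dimethylamino gave only a 2.2-fold lower number from compound 2 to compound 3 (0.34 log units; beyond the scatter) as a modest one. The ester tells the same story from a second starting point, since replacing ethoxycarbonyl with 2-hydroxyethyl gives a 5.6-fold higher number from compound 2 to compound 4 (0.75 log units; beyond the scatter) as a modest step in the same direction. Among compounds 2, 3 and 4, which can be compared in this way, both compounds with a carbonyl in this chain therefore have lower numbers than the alcohol, and neither goes against that pattern.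

No supporting evidence explains why the number rises when this change is made. Also open, as far as these compounds go, is how a 3-methoxypropyl chain, with an oxygen but no hydroxyl hydrogen, or a 3-aminopropyl chain would read here, and so whether the departure of the carbonyl or the arrival of the hydroxyl carries most of the step.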